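Shortening the octyl chain of compound 1 to propyl

The source may hold more compounds than are shown below. What is called first, only, known or untested is meant among the compounds shown, and "the series" means these compounds.

Measured so far:
compound 1, `CCCCCCCCc1cn([C@H]2C[C@H](O)[C@@H](CO)O2)c(=O)[nH]c1=O`, 66 ug/mL
compound 2, `CCCc1cn([C@H]2C[C@@H]3OP(=O)(O)OC[C@H]3O2)c(=O)[nH]c1=O`, > 500 ug/mL
compound 3, `CC(C)c1cn([C@H]2C[C@@H]3OP(=O)(O)OC[C@H]3O2)c(=O)[nH]c1=O`, > 500 ug/mL

Among the measured compounds shown here, in a functional assay on L1210 cells (Mus musculus) (on this read-out higher numbers stand for weaker inhibition and lower numbers for stronger inhibition), compound 1 gives 66 ug/mL, and this is the only number among the three values shown. Compound 2 gives only a limit of the assay, > 500 ug/mL. Compound 3 likewise gives only a limit, > 500 ug/mL. The step that the two limits leave unreadable from compound 2 to compound 3 therefore cannot be read, since the limit of > 500 ug/mL in this assay, at which 2 of the 3 values shown sit, covers both ends of it.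

Compound 4 is `CCCc1cn([C@H]2C[C@H](O)[C@@H](CO)O2)c(=O)[nH]c1=O`. It differs from compound 1 by hydrogen in place of pentyl on a saturated chain carbon, three bonds along the chain from an aromatic carbon. For the measured compounds named here, no measured step bears directly on this change: compound 2 carries a propyl group as compound 4 does, but on a different core and with only a limit as its value, so it gives no size for the step. The step of a 3.8-fold higher number from compound 1 to compound 4 (0.58 log units; beyond the scatter) is therefore an expectation without a measured counterpart, towards weaker inhibition. Compound 4 is expected to give about 250 ug/mL, within a range from 60 ug/mL to 1000 ug/mL.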

Compound 4, concentration for 50% inhibition: > 500 ug/mL
Compound 4 was reported as a limit; the forecaster's own chance of this, stated with the estimate: 40%; at least 2.0-fold (0.30 log units) between middle value and limit.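

Among the compounds shown here, on the core of compound 1, shortening octyl to propyl gives the first readable step at this position: in this assay the change is an at least 7.5-fold higher number from compound 1 to compound 4 (0.87 log units; beyond the scatter), towards weaker inhibition. Compound 2 and compound 3 also carry short chains, but they sit on a different core and gave no such reading. The step has a lower end only, and its full size stays unknown, because the value for compound 4 is a limit: the limit of > 500 ug/mL in this assay, at which 3 of the 4 values shown sit.

The compounds shown leave open how inhibition runs on this core for chains between propyl and octyl, such as pentyl, and whether a longer chain such as decyl would lower the number further. They also leave open what an amine or a carboxylic acid in place of the chain would give, and whether an octyl chain would bring the core of compound 2 to a readable number.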